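The compounds below may be only part of what the source reports. "The series", "measured", "known", "first", "only" and "open" are said of these compounds alone.

Compound 2 `NC(=O)c1nc(C#Cc2ccccc2)n(COCCO)n1` is the starting point. In an ADME assay on cells (Homo sapiens) for cytotoxicity (a higher number here means that more compound is tolerated, a lower number that less compound is tolerated), compound 2 gives > 170000 nM, which is a limit of the assay rather than a measured number. Within the data shown here, its only measured neighbour is compound 1 `NC(=O)c1nc(C#Cc2ccc(F)cc2)n(COCCO)n1`, which carries a fluoro on the aromatic ring where compound 2 carries hydrogen. In this assay compound 1 gives > 160000 nM, which is also a limit. The step that the two limits leave unreadable from compound 1 to compound 2 is therefore unreadable, as both of its ends are limits. For compound 1 that end is the limit of > 160000 nM in this assay, at which 1 of the 2 values shown sits. For compound 2 that end is the limit of > 170000 nM in this assay, at which 1 of the 2 values shown sits.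

Compound 3 `NC(=O)c1nc(C#Cc2ccc(C(F)(F)F)cc2)n(COCCO)n1` differs from compound 2 by trifluoromethyl in place of hydrogen on an aromatic carbon. Among the measured compounds shown here, no measured step bears on this exchange in a readable way; all that is known is that compound 1 and compound 2 were each tolerated up to the limit. On that basis compound 3 is expected to be tolerated to a similar degree, with the step of an at least 1.1-fold lower number from compound 2 to compound 3 (0.05 log units; that floor lies within the scatter) estimated as none beyond the scatter, and most likely reported again only as a limit. The estimate for compound 3 in this assay is 150000 nM, with a range from 60000 nM to 300000 nM.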

Compound 3, half-maximal cytotoxic concentration: 79000 nM
Beside the measured number, compound 3's estimate is 1.9-fold (0.28 log units) above it, within the range that was stated.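

Trifluoromethyl in place of hydrogen on an aromatic carbon, para to a large group, is the first change here with a readable result in this assay, showing that this position is not indifferent to what it carries: the result is an at least 2.1-fold lower number from compound 2 to compound 3 (0.33 log units; beyond the scatter). That size is only a floor, because compound 2 stands at a limit of the assay and not at a measured number: the limit of > 170000 nM in this assay, at which 1 of the 3 values shown sits. Trifluoromethyl in place of fluoro gives an at least 2.0-fold lower number from compound 1 to compound 3 (0.30 log units; that floor lies within the scatter), a floor that does not on its own clear the scatter, because the starting end of this step is also a limit: the limit of > 160000 nM in this assay, at which 1 of the 3 values shown sits.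

With a single measured number in the series, the compounds shown cannot tell how far below the limits compound 3 really lies, or whether the drop in tolerated compound follows from trifluoromethyl alone or would appear with other groups at this place. A chloro, a methoxy, an amine or a carboxylic acid on the same aromatic carbon would show whether compound 3 is a lone case or part of a trend.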